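This account rests on a few compounds, and the source may have more. Where it says the series, first, only, none or still open, it means among the compounds named here.

In an ADME assay on microsomes from liver (Mus musculus, strain CD-1) for metabolic stability, read by LC-MS, tested at 2 uM (a lower number here means that the compound disappears faster, a higher number that the compound lasts longer), three compounds that share one core differ only in what sits on a sulfonamide nitrogen. Compound 1 `Cn1ccc2ccc(-c3cc(Nc4ccccc4S(N)(=O)=O)cc4nccnc34)cc21`, with hydrogen there, gives 0.5 h. Compound 2 `CNS(=O)(=O)c1ccccc1Nc1cc(-c2ccc3ccn(C)c3c2)c2nccnc2c1`, with methyl, gives 0.2 h. Compound 3 `CN1CCC(NS(=O)(=O)c2ccccc2Nc2cc(-c3ccc4ccn(C)c4c3)c3nccnc3c2)C1`, with 1-methylpyrrolidin-3-yl, gives 0.667 h. Adding the 1-methylpyrrolidin-3-yl group to the hydrogen compound gives a 1.3-fold higher number from compound 1 to compound 3 (0.13 log units; within the scatter), so those two cannot be told apart. Adding methyl instead gives a 2.5-fold lower number from compound 1 to compound 2 (0.40 log units; beyond the scatter), and exchanging methyl for 1-methylpyrrolidin-3-yl gives a 3.3-fold higher number from compound 2 to compound 3 (0.52 log units; beyond the scatter).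

The next compound is compound 4 `CN(Cc1cncnc1)S(=O)(=O)c1ccccc1Nc1cc(-c2ccc3ccn(C)c3c2)c2nccnc2c1`, and the change from compound 3 is methyl((pyrimidin-5-yl)methyl)amino in place of (1-methylpyrrolidin-3-yl)amino on a sulfonyl sulfur. All three measured steps bear on this change. Within the data shown here, they alter the same part of the molecule, but none of the measured compounds carries a pyrimidin-5-yl group. Only the size of those steps can guide the expectation, and none was more than modest. Among the measured compounds shown here, the numbers so far run from compound 2 at 0.2 h to compound 3 at 0.667 h, so a lower number seems somewhat likelier than a higher one, though no step beyond the scatter is expected in this assay. The estimate amounts to a 1.7-fold lower number from compound 3 to compound 4 (0.22 log units; within the scatter). Compound 4 is expected to give 0.4 h, within an estimated range of 0.15 h to 1 h.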

Compound 4, half-life: 0.2 h
Compound 4: the middle estimate sits 2.0-fold (0.30 log units) above what was measured; low and high end bracket the measured number.
By their numbers in this assay, from the lowest: compounds 2 and 4 (each within the scatter of the next); then compounds 1 and 3 (each within the scatter of the next).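

In this assay the move from (1-methylpyrrolidin-3-yl)amino to methyl((pyrimidin-5-yl)methyl)amino on the sulfonyl sulfur gives a 3.3-fold lower number from compound 3 to compound 4 (0.52 log units; beyond the scatter) and so shows that the larger of these two groups, counted by heavy atoms, does not hold the number up. Set against the methyl compound, placing (pyrimidin-5-yl)methyl in place of hydrogen on the sulfonamide nitrogen gives no change at the digits printed from compound 2 to compound 4 (within the scatter) and so leaves the number where methyl alone had put it. Set against the unsubstituted sulfonamide, the change gives a 2.5-fold lower number from compound 1 to compound 4 (0.40 log units; beyond the scatter) and so adds a second case to a pattern seen only in these four compounds, with none going against it: compound 2 and compound 4, the two with a methyl directly on the sulfonamide nitrogen, both sit lower than compound 1 and compound 3.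

Why the numbers fall this way remains open, as nothing measured here speaks to it. As far as these compounds go, it is also open whether dimethylamino on the sulfonyl sulfur, or a benzyl group in place of (pyrimidin-5-yl)methyl, would follow the same pattern.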